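The source may hold more compounds than are shown below. What is called first, only, known or untested is meant among the compounds shown, and "the series" means these compounds.

Compound 1 `CC1=CC[C@H](C(C)(C)NC(=S)N/N=C/c2ccccc2O)CC1` is the reference point of this small set. Among the measured compounds shown here, in an ADME assay on Vero cells (Chlorocebus sabaeus) for inhibition, read by sulforhodamine B assay, with a stated time of 48 h (a higher number here means a weaker inhibitor of growth, a lower number a stronger inhibitor of growth), compound 1 gives 11200 nM, the only plain number among the three measured compounds. Compound 2 `CC1=CC[C@H](C(C)(C)NC(=S)N/N=C/c2ccccc2[N+](=O)[O-])CC1` swaps the hydroxy group for a nitro group; in this assay compound 2 returns only a limit, > 100000 nM. Compound 3 `CC1=CC[C@H](C(C)(C)NC(=S)N/N=C/c2cccc([N+](=O)[O-])c2)CC1` also carries a nitro group on the aromatic ring; in this assay compound 3 likewise returns a limit, > 100000 nM. For the measured compounds named here, the one measured step, an at least 8.9-fold higher number from compound 1 to compound 2 (0.95 log units; beyond the scatter), can be given only as a bound because of the limit of > 100000 nM in this assay, at which 2 of the 3 values shown sit, but it shows that replacing the hydroxy group cost a clear share of growth inhibition.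

Compound 4 `CC1=CC[C@H](C(C)(C)NC(=S)N/N=C/c2ccc[nH]2)CC1` differs from compound 1 in a different way: 1H-pyrrol-2-yl in place of 2-hydroxyphenyl on a carbon with a double bond to nitrogen. Going by the values given here, the incoming ring keeps a hydrogen-bond donor but loses the acceptor, and the only comparable measured change, from hydroxy to nitro, weakened inhibition. The change from compound 1 to compound 4 is therefore expected to weaken inhibition modestly, roughly a 2.7-fold higher number from compound 1 to compound 4 (0.43 log units; beyond the scatter). Compound 4 is estimated at 30000 nM in this assay, within a range from 8000 nM to 100000 nM.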

Compound 4, concentration for total growth inhibition: > 100000 nM
Compound 4: a limit, no number (the forecaster's own chance of this, stated with the estimate: 35%); middle value at least 3.3-fold (0.52 log units) from the limit.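

In this assay, the loss of growth inhibition is not tied to the nitro group: replacing the whole 2-hydroxyphenyl with 1H-pyrrol-2-yl gives an at least 8.9-fold higher number from compound 1 to compound 4 (0.95 log units; beyond the scatter). The incoming ring has the same count of hydrogen-bond donors as the one it replaces, so keeping that count did not preserve a measurable value in this comparison. This step is only a bound, and compound 1 is now the only compound with a plain number: the limit of > 100000 nM in this assay, at which 3 of the 4 values shown sit.

Steps among compound 2, compound 3 and compound 4 cannot be read, as each of their values is a limit. As far as these compounds go, it remains open whether an amine or a methoxy group in place of the hydroxy group would keep a value that can be read in this assay.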